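The compounds below may be only part of what the source reports. "The series", "measured", "known", "first", "only" and "open" are said of these compounds alone.

Of the compounds shown here, three sharing one core have been read in a functional assay on MCF7 cells (Homo sapiens), read by MTT assay, with a stated time of 48 h; on this read-out lower numbers stand for stronger inhibition and higher numbers for weaker inhibition. Compound 1 (`CCOC(=O)CN(C)C(=O)c1ccc(C(CC)(CC)c2ccc(OCC(O)C(C)(C)C)c(C)c2)n1CC`) gives 9200 nM. Compound 2 (`CCn1c(C(=O)N(C)CCC#N)ccc1C(CC)(CC)c1ccc(OCC(O)C(C)(C)C)c(C)c1`) gives only a limit, > 50000 nM. Compound 3 (`C=CCN(C)C(=O)c1ccc(C(CC)(CC)c2ccc(OCC(O)C(C)(C)C)c(C)c2)n1CC`) also gives only a limit, > 50000 nM, so it has no exact position on the scale. Two measured steps start from compound 1: cyanomethyl in place of ethoxycarbonyl gives an at least 5.4-fold higher number from compound 1 to compound 2 (0.73 log units; beyond the scatter), and vinyl in its place gives an at least 5.4-fold higher number from compound 1 to compound 3 (0.73 log units; beyond the scatter). Compound 4 (`CC[C@@H](C)[C@H](NC(=O)c1ccc(C(CC)(CC)c2ccc(OCC(O)C(C)(C)C)c(C)c2)n1CC)C(=O)O`) differs from compound 3 at the amide: (1-carboxy-2-methylbutyl)amino in place of allyl(methyl)amino on a carbonyl carbon. In words, (1-carboxy-2-methylbutyl)amino stands in place of allyl(methyl)amino on a carbonyl carbon. For the measured compounds named here, no measured step tests this exchange, so those two steps bear on it only indirectly. Going by the values given here, they show that the side chain can move the read-out, with compound 1 at 9200 nM the only exact number nearby. A modest move towards a lower number is therefore expected, though compound 4 may well remain at the limit. The expected step is an at least 1.6-fold lower number from compound 3 to compound 4 (0.22 log units; that floor lies within the scatter). The estimate for compound 4 is 30000 nM, with an expected range from 8000 nM to 60000 nM.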

Compound 4, half-maximal inhibitory concentration: 2000 nM
Estimate against measurement, compound 4: 15-fold (1.18 log units) above, and the stated range ends above it.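

In this assay, the exchange on the carbonyl carbon gives an at least 25-fold lower number from compound 3 to compound 4 (1.39 log units; beyond the scatter) and an at least 25-fold lower number from compound 2 to compound 4 (1.39 log units; beyond the scatter), and both of these steps start from a limit rather than a number: the limit of > 50000 nM in this assay, at which 2 of the 4 values shown sit. The earlier steps shown here only led to higher numbers than that of compound 1, whereas (1-carboxy-2-methylbutyl)amino goes past it, with a 4.6-fold lower number from compound 1 to compound 4 (0.66 log units; beyond the scatter). Compound 4 is therefore the strongest of the four, and the group on this carbonyl carbon is shown to lower the number as well as raise it.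

The compounds shown leave open whether the step belongs to the free carboxylic acid, the branched chain or the two defined stereocentres. An ethyl ester of the same chain, or a carboxylic acid on a shorter unbranched chain, would separate these parts.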